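A few compounds are considered here, and "the series" means these few. Any claim that something is new, unique, unknown or untested is made for them only; others in the source may bear on it.

Of the compounds shown here, three have been measured in an ADME assay on the whole organism (strain CD) for pharmacokinetics, with Rattus norvegicus as the target, at a dose of 1 mg/kg (a higher number here means faster removal of the compound, a lower number slower removal), and share one core. Compound 1 `CC(=O)NCc1cccc(Cn2nc(NS(=O)(=O)c3ccc(Cl)s3)c3c(O)cccc32)c1` gives 19 mL/min/kg. Compound 2 `CC(=O)NCc1cccc(Cn2nc(NS(=O)(=O)c3ccc(Cl)s3)c3c(C(C)O)cccc32)c1` gives 13 mL/min/kg, and the step of a 1.5-fold lower number from compound 1 to compound 2 (0.16 log units; within the scatter) sits on a different part of the molecule from the one that matters here. Compound 3 `CN[C@H](C)C(=O)NCc1cccc(Cn2nc(NS(=O)(=O)c3ccc(Cl)s3)c3c(OC)cccc32)c1` gives 17 mL/min/kg, the second highest of the three, with both other compounds within the scatter of it. Compound 4 `COc1cccc2c1c(NS(=O)(=O)c1ccc(Cl)s1)nn2Cc1cccc(CNC(=O)C(C)(C)N)c1` has not yet been measured and differs from compound 3 by 1-amino-1-methylethyl in place of 1-(methylamino)ethyl on a carbonyl carbon. Within the data shown here, no measured step touches this part of the molecule, and the only measured step lies within the scatter. For compound 4 the expected step is no change at the digits printed from compound 3 to compound 4 (within the scatter), nothing beyond the scatter. Compound 4 is therefore estimated at 17 mL/min/kg, between 9 mL/min/kg and 32 mL/min/kg.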

Compound 4, clearance in the Rattus norvegicus assay: 15 mL/min/kg
Estimate against measurement, compound 4: 1.1-fold (0.05 log units) above; measured number inside the range.
By their numbers in the Rattus norvegicus assay, from the lowest: compounds 2, 4, 3 and 1 (each within the scatter of the next).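

In the Rattus norvegicus assay compound 3 gives 17 mL/min/kg and compound 4 gives 15 mL/min/kg. Among these compounds, in the Rattus norvegicus assay, 1-amino-1-methylethyl in place of 1-(methylamino)ethyl on this carbonyl carbon amounts to a 1.1-fold lower number from compound 3 to compound 4 (0.05 log units; within the scatter), the first measured step at this position, and it loses the defined stereocentre without a step beyond the scatter. Nothing at hand explains this result. In a physicochemical assay for acid dissociation, compound 3 is reported as "not determined" (no result reported) and compound 4 as "not determined" (no result reported), so no step can be read there. Still open, as far as these compounds go, is whether a carboxylic acid, or a longer chain carrying the amine, on this carbonyl carbon would stay within the scatter of compound 3 in the Rattus norvegicus assay.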